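A smaller ring on the nitrogen of compound 3

A few compounds are considered here, and "the series" means these few. Any claim that something is new, unique, unknown or untested is made for them only; others in the source may bear on it.

For the measured compounds named here, in an ADME assay on a cell-free system (plasma, Rattus norvegicus, strain Wistar) for metabolic stability, read by HPLC, tested at 1 uM (on this read-out higher numbers stand for a longer-lived compound and lower numbers for a shorter-lived compound), compound 3 (`O=C(NC1CCCCC1)Oc1cccc(-c2ccccc2)c1`) gives 0.712 h, the highest of the three numbers measured so far. Compound 1 (`CCCCCCNC(=O)Oc1cccc(-c2ccccc2)c1`) gives 0.125 h, and compound 2 (`NC(=O)c1cccc(-c2cccc(OC(=O)NCCCCc3ccccc3)c2)c1`) gives 0.07 h. Both of these numbers lie beyond the scatter below that of compound 3.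

Compound 4 (`O=C(NC1CCC1)Oc1cccc(-c2ccccc2)c1`) has not yet been measured. It differs from compound 3 in one place: cyclobutyl in place of cyclohexyl on an amide-type nitrogen. In words, cyclobutyl stands in place of cyclohexyl on an amide-type nitrogen.

Going by the values given here, only one measured step bears on this change: a 5.7-fold higher number from compound 1 to compound 3 (0.76 log units; beyond the scatter). That step, modest but beyond the scatter, put cyclohexyl in place of hexyl at the same place. It therefore compares a ring with a chain, not one ring with another, and serves only as a rough guide. Among the compounds with values here, no single-place step connects compound 2 to the other compounds, and no measured compound carries a second ring at this place.

Compound 4 keeps a ring, so a fall smaller than the rise seen in that step seems likely, though this is an expectation on thin evidence. The expected change is a 2.0-fold lower number from compound 3 to compound 4 (0.31 log units; beyond the scatter). For compound 4 the estimated half-life is 0.35 h, with an expected range from 0.12 h to 0.9 h.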

Compound 4, half-life: 0.332 h
Compound 4: middle estimate off by 1.1-fold (0.02 log units), on the high side; measured number inside the range.
By their numbers in this assay, from the lowest: compounds 2 and 1 (each within the scatter of the next); then compound 4; then compound 3.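

In this assay, for the compounds shown here, the step of a 2.1-fold lower number from compound 3 to compound 4 (0.33 log units; beyond the scatter) gives the first direct comparison of one ring with another on this amide-type nitrogen, and it shows that going from the six-membered to the four-membered ring alone moves the half-life beyond the scatter. The smaller ring does not lose the whole gain seen with cyclohexyl over hexyl: the step of a 2.7-fold higher number from compound 1 to compound 4 (0.42 log units; beyond the scatter) still lies beyond the scatter, so among compound 1, compound 3 and compound 4, both rings give longer half-lives than the hexyl chain, with cyclohexyl the longest. Nothing shown explains why the half-life follows the group at this place.

On these data alone, two ring sizes fix no trend, so it remains open whether cyclopentyl would fall between compound 4 and compound 3, or whether a methyl or hydroxyl group on the ring would shift the number further. Also open, as far as these compounds go, is whether a shorter chain such as butyl on the same nitrogen would stay below the rings, which leaves it unsettled whether the ring itself or the length of the hexyl chain sets the gap.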